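This account rests on a few compounds, and the source may have more. Where it says the series, first, only, none or still open, it means among the compounds named here.

Values in a functional assay on A-375 cells (Homo sapiens) for cytotoxicity, read by CCK-8 assay, with a stated time of 24 h; a higher number here means a weaker inhibitor, a lower number a stronger inhibitor:
- compound 1 `COc1ccccc1Oc1c(N)nc(-c2cccc(Cl)c2)nc1OCCO`: 30200 nM
- compound 2 `COc1ccccc1Oc1c(N)nc(-c2ccc(Cl)cc2)nc1OCCO`: > 80000 nM, a limit of the assay and not a number
- compound 3 `COc1ccccc1Oc1c(N)nc(-c2cccc(Br)c2)nc1OCCO`: 650 nM

Compound 3 holds the lowest number of the set. The steps leading to it are a 46-fold lower number from compound 1 to compound 3 (1.67 log units; beyond the scatter) and an at least 120-fold lower number from compound 2 to compound 3 (2.09 log units; beyond the scatter), both large.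

The next candidate is compound 4 `COc1ccccc1Oc1c(N)nc(-c2ccc(Br)cc2)nc1OCCO`, with 4-bromophenyl in place of 3-bromophenyl on an aromatic carbon, between two ring nitrogen atoms: 4-bromophenyl in place of 3-bromophenyl on an aromatic carbon.

The one matching move in the set is an at least 2.6-fold higher number from compound 1 to compound 2 (0.42 log units; beyond the scatter), which is beyond the scatter. Going by these compounds, it ends at a limit, so its full size stays open. The large step on exchanging chloro for bromo warns that the two halogen pairs need not behave alike, since a 46-fold lower number from compound 1 to compound 3 (1.67 log units; beyond the scatter) rests on a single comparison. A higher number is therefore expected in this assay, of moderate to large size.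

The expected change is a 9.2-fold higher number from compound 3 to compound 4 (0.97 log units; beyond the scatter). Compound 4 is estimated at 6000 nM, with an expected range of 1200 nM to 40000 nM.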

Compound 4, half-maximal inhibitory concentration: 10300 nM
The estimate for compound 4 lay 1.7-fold (0.23 log units) below the measured number; the range from low to high includes it.
By their numbers in this assay, from the lowest: compound 3; then compound 4; then compound 1. At a limit, above all of these: compound 2.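

In this assay, the bromine's shift gives a 16-fold higher number from compound 3 to compound 4 (1.20 log units; beyond the scatter), so the change from 3-bromophenyl to 4-bromophenyl now has a full size, with both ends measured as numbers. Bromo in place of chloro also lowers the number on the 4-substituted pair, with an at least 7.7-fold lower number from compound 2 to compound 4 (0.89 log units; beyond the scatter), a step that starts from a limit of the assay and not a number. Changing the halogen and its place together gives a 2.9-fold lower number from compound 1 to compound 4 (0.47 log units; beyond the scatter), and the exchange of chloro for bromo runs the same way in both pairs, though its size is not settled: the same change on two cores in this assay, a 46-fold lower number (1.67 log units; beyond the scatter) from compound 1 to compound 3 and an at least 7.7-fold lower number (0.89 log units; beyond the scatter) from compound 2 to compound 4; the limit leaves it open whether they differ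

Going by these compounds, whether a methoxy group or a nitrile on this phenyl ring would follow the same order remains open. So does whether these steps would hold if the 2-hydroxyethoxy group gave way to an amine or a longer chain.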